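The source may report more compounds than this note shows. Statements on the series, on what has been measured and on what is new or still open speak of the compounds shown alone.

Compound 1, `O=C(/C=C/c1ccc(OCCCCCO[N+](=O)[O-])c(O)c1)OCCCCCO[N+](=O)[O-]`: in a functional assay on LOX IMVI cells (Homo sapiens) for cytotoxicity, read by resazurin assay, with a stated time of 72 h (a higher number here means a weaker inhibitor, a lower number a stronger inhibitor), compound 1 gives 7230 nM.
Compound 2, `O=C(/C=C/c1ccc(OCCCCO[N+](=O)[O-])c(O)c1)OCCCCO[N+](=O)[O-]`: in this assay compound 2 reaches only a limit of the measurement, > 50000 nM.
Compound 3, `COc1cc(/C=C/C(=O)OCCCCCO[N+](=O)[O-])ccc1OCCCCCO[N+](=O)[O-]`: in this assay compound 3 likewise reaches only a limit of the measurement, > 50000 nM.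

Compound 1 and compound 3 share a core and differ in a single place: methyl in place of hydrogen on an oxygen on an aromatic ring. That change produced an at least 6.9-fold higher number from compound 1 to compound 3 (0.83 log units; beyond the scatter), a step that coincides with the limit of > 50000 nM in this assay, at which 2 of the 3 values shown sit. Compound 2 rests on a different core; how it differs from compound 1 is not broken down here.

Compound 4, `COc1cc(/C=C/C(=O)OCCCCO[N+](=O)[O-])ccc1OCCCCO[N+](=O)[O-]`, has not yet been measured. It stands to compound 2 exactly as compound 3 stands to compound 1: methyl in place of hydrogen on an oxygen on an aromatic ring. The place of the change reads the same in both pairs, so this is the same change made a second time. In the first pair it weakened the compound beyond the usual scatter.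

Compound 2 already gives only the limit > 50000 nM in this assay. Compound 4 is therefore expected to give 120000 nM in this assay, most likely again reported only as a limit. For compound 4 the expected step is a step that the limit leaves unreadable from compound 2 to compound 4, mirroring what the same change did from compound 1 to compound 3. Compound 4 is expected to fall between 50000 nM and 400000 nM.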

Compound 4, half-maximal inhibitory concentration: > 50000 nM
Compound 4: only a limit was reported; the forecaster's own chance of this, stated with the estimate: 85%; the middle value lies beyond the limit too.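

In this assay compound 4 gives > 50000 nM, which is a limit of the assay and not a number. Compound 2 also stands at a limit, so no step between compound 2 and compound 4 can be read: the limit of > 50000 nM in this assay, at which 3 of the 4 values shown sit.

The compounds shown leave open whether the change from hydroxy to methoxy weakens compound 2 in the way it weakened compound 1.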